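The compounds below may be only part of what the source reports. "The series", "measured", "known", "first", "only" and "open" are said of these compounds alone.

Measured compounds:
compound 1 `CCN1C(=O)N(CC)C2C1NC(=S)N2/N=C/C=C/c1ccccc1OC` gives 250 nM in a functional assay on RD cells (Homo sapiens) for inhibition, read by MTT assay, with a stated time of 72 h; a lower number here means a stronger inhibitor, a higher number a weaker inhibitor
compound 2 `CCN1C(=O)N(c2ccccc2)C2NC(=S)N(/N=C/C=C/c3ccccc3)C21` gives 470 nM in this assay

Compound 2 holds the higher of the two numbers in this assay, but compound 1 sits close by, and the gap between the two values lies within the scatter of repeat measurements, so the two cannot be ranked against each other. Going by the values given here, the two compounds also differ in more than one place, so no single step can be drawn between them.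

Compound 3 `CCN1C(=O)N(c2ccccc2)C2NC(=S)N(/N=C/C=C/c3ccccc3OC)C21` is the compound not yet measured. It differs from compound 2 in one place: methoxy in place of hydrogen on an aromatic carbon. Compound 1 already carries the methoxy group on the same aromatic ring, with a different substituent pattern on the core, and its value in this assay is not separated from that of compound 2 beyond the scatter. Nothing in the measured pair therefore points to a change of any size beyond the scatter for this addition. The step from compound 2 to compound 3 is expected to be small, a 1.3-fold lower number from compound 2 to compound 3 (0.10 log units; within the scatter), in either direction. Compound 3 is estimated to give 370 nM in this assay, with a range from 150 nM to 900 nM.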

Compound 3, half-maximal inhibitory concentration: 45900 nM
Compound 3: the middle estimate sits 120-fold (2.09 log units) below what was measured; measured number above the stated range.
By their numbers in this assay, from the lowest: compounds 1 and 2 (each within the scatter of the next); then compound 3.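

In this assay, methoxy in place of hydrogen on the aromatic carbon, ortho to a large group, is far from a neutral addition when phenyl sits on the amide-type nitrogen in a ring: the change gives a 98-fold higher number from compound 2 to compound 3 (1.99 log units; beyond the scatter) and is a large step. The 2-(2-methoxyphenyl)ethenyl arm is not poor in every setting, since changing only ethyl to phenyl on that nitrogen gives a 180-fold higher number from compound 1 to compound 3 (2.26 log units; beyond the scatter) and is also a large step, so within these compounds the high number appears only where methoxy and phenyl occur together. No measurement on these compounds offers an explanation for either step.

The compounds shown leave open whether the sharp rise belongs to methoxy itself or would also follow another group on the same aromatic carbon, such as a hydroxyl, a fluorine atom or an ethoxy. They also leave open how hydrogen at this position behaves with ethyl on the nitrogen, and so whether the two changes act independently or only in combination.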